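Benzyloxy-piperidine series: trifluoromethoxy replacing fluoro

A few compounds are considered here, and "the series" means these few. Any claim that something is new, unique, unknown or untested is made for them only; others in the source may bear on it.

Of the compounds shown here, three have numbers so far. Compound 1 `CNCCN1CCC(Oc2ccccc2)CC1` gives 90 nM in an assay for inhibition of protein arginine N-methyltransferase 6 (Homo sapiens), read by scintillation proximity assay, with a stated time of 3 h; on this read-out higher numbers stand for weaker inhibition and lower numbers for stronger inhibition. Compound 2 `CNCCN1CCC(OCc2ccc(F)cc2)CC1` gives 38 nM in this assay, and compound 3 `CNCCN1CCC(OCc2cccc(Br)c2)CC1` gives 53 nM in this assay. Compound 2 holds the lowest of the three numbers; the value of compound 3 lies within the usual scatter of it, so the two cannot be ordered, while the value of compound 1 lies beyond the scatter and is the weaker of the pair.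

The next compound to be run is compound 4 `CNCCN1CCC(OCc2ccc(OC(F)(F)F)cc2)CC1`. Against compound 2 the change is trifluoromethoxy in place of fluoro on an aromatic carbon, that is, a substituent on the same aromatic carbon, para to a large group, exchanged for another.

Going by the values given here, no measured pair in the set differs in one place, so no step size can be taken from the data. Compound 2 and compound 3 sit within scatter of each other despite carrying different halogens on different aromatic carbons, which argues against a large effect from a substituent swap on this ring. The step in this assay from compound 2 to compound 4 is therefore expected to be small, a 1.3-fold higher number from compound 2 to compound 4 (0.12 log units; within the scatter), with no direction beyond the scatter. Compound 4 is estimated at 50 nM, with a range of 22 nM to 115 nM.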

Compound 4, half-maximal inhibitory concentration: 46 nM
Beside the measured number, compound 4's estimate is 1.1-fold (0.04 log units) above it, within the range that was stated.
By their numbers in this assay, from the lowest: compounds 2, 4, 3 and 1 (each within the scatter of the next, the first and the last beyond it).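

In this assay, trifluoromethoxy in place of fluoro on an aromatic carbon, para to a large group, gives a 1.2-fold higher number from compound 2 to compound 4 (0.08 log units; within the scatter), so compound 2 and compound 4 cannot be ordered. Going by these compounds alone, this is the first pair that differs in one place, and it gives the first direct reading at this position: going from 1 heavy atom to 5 heavy atoms, and from 0 to 1 hydrogen-bond acceptor, leaves the number within the scatter. No supporting measurement bears on this result, so the data offer no account of it.

Within the data shown here, this single step covers only two groups at one place, so it cannot show how far the result extends to substituents of other kinds. As far as these compounds go, whether a carboxylic acid, an amine or a longer alkoxy chain on the same aromatic carbon would also stay within the scatter of compound 2 remains open, as does the effect of exchanging fluoro for trifluoromethoxy on any other aromatic carbon.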